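The compounds below may be only part of what the source reports. "The series", "measured", "known", "first", "only" and "open" are said of these compounds alone.

Measured so far:
compound 1 `O=C1N/C(=N/N=C/c2c(-c3ccc(Br)cc3)[nH]c3ccccc23)SC1CCO` gives 15900 nM
compound 2 `CCOC(=O)c1sc(N/N=C/c2c(-c3ccc(Cl)cc3)[nH]c3ccccc23)nc1C` gives 25200 nM

Both compounds were tested in an ADME assay on MRC5 cells (Homo sapiens) for cytotoxicity, read by fluorescence, with a stated time of 24 h; a higher number here means a weaker inhibitor, a lower number a stronger inhibitor. Among the compounds with values here, compound 1 has the lower of the two numbers, but its only neighbour, compound 2, sits within the scatter of repeated measurements, so neither compound can be called the stronger or weaker inhibitor on these figures. Compound 3 `CCC1S/C(=N\N=C\c2c(-c3ccc(Br)cc3)[nH]c3ccccc23)NC1=O` has not yet been tested. It differs from compound 1 in one place: hydrogen in place of hydroxy on a saturated chain carbon, two bonds along the chain from a saturated ring carbon. Within the data shown here, no step between two measured compounds is known, so nothing in these data shows what removing a hydroxy group does in this assay. For the step from compound 1 to compound 3 the expectation is therefore a 1.1-fold lower number from compound 1 to compound 3 (0.06 log units; within the scatter), a change no larger than the scatter, in either direction. Compound 3 is expected to give about 14000 nM, with a likely range from 5000 nM to 40000 nM.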

Compound 3, half-maximal inhibitory concentration: 5910 nM
The estimate for compound 3 lay 2.4-fold (0.37 log units) above the measured number, within the range that was stated.
By their numbers in this assay, from the lowest: compound 3; then compounds 1 and 2 (each within the scatter of the next).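

Replacing hydroxy with hydrogen on a saturated chain carbon, two bonds along the chain from a saturated ring carbon, gives a 2.7-fold lower number from compound 1 to compound 3 (0.43 log units; beyond the scatter) in this assay. Within the data shown here, the earlier compounds offered no single-place comparison, so this is the first sign that this position can move the number beyond the scatter: going from 2-hydroxyethyl to ethyl makes compound 3 the stronger inhibitor of the pair. It is one modest step from one pair of compounds, and no supporting measurement here says why the number moves.

The compounds shown leave open how an amine or a carboxylic acid in place of the hydroxy, or a longer chain, would read at this position. Also open, from the compounds shown here alone, is whether the same change gives a step of this size on a different core.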